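Phenoxy on the benzyl ring of compound 1

The source may hold more compounds than are shown below. What is called first, only, known or untested is meant among the compounds shown, and "the series" means these compounds.

Compound 1 `Nc1nc(NCc2ccccc2)nc(-c2ccccc2CO)n1` is the starting point. In a functional assay on cells for positive allosteric modulation of G-protein coupled receptor 68 (Homo sapiens), read by a luciferase reporter and cAMP accumulation, with a stated time of 30 min, at pH 6.8 and pH 8.3, in the presence of a further agent that is not named here (a higher number here means a more potent compound, by a factor of ten per unit of this negative logarithm, a lower number a less potent compound), compound 1 gives 4.35, which is the second highest of the three numbers at hand. Its neighbour compound 2 `COc1cccc(-c2nc(N)nc(NCc3ccccc3)n2)c1CO` gives 4.16, and the step of a number 0.19 log units lower from compound 1 to compound 2 (within the scatter) comes from methoxy in place of hydrogen on an aromatic carbon. Compound 3 `Cc1ccccc1CNc1nc(N)nc(-c2ccccc2CO)n1` gives 4.7, and the step of a number 0.35 log units higher from compound 1 to compound 3 (beyond the scatter) comes from methyl in place of hydrogen on an aromatic carbon.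

Compound 4 `Nc1nc(NCc2ccc(Oc3ccccc3)cc2)nc(-c2ccccc2CO)n1` differs from compound 1 as follows: phenoxy in place of hydrogen on an aromatic carbon. Both measured steps swap a hydrogen for a small group on an aromatic carbon; the only one beyond the scatter, a number 0.35 log units higher from compound 1 to compound 3 (beyond the scatter), was a modest gain. Neither step involves a group as large as phenoxy, so the bearing is loose. A small gain or no change beyond the scatter is expected, and the step is estimated as a number 0.25 log units higher from compound 1 to compound 4 (within the scatter). Compound 4 is estimated at 4.6, with a range from 4.1 to 5.1.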

Compound 4, negative logarithm of the antagonist equilibrium constant: 5.19
Compound 4: middle estimate off by 0.59 log units, on the low side; the whole stated range lies below it.
By their numbers in this assay, from the lowest: compounds 2 and 1 (each within the scatter of the next); then compound 3; then compound 4.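

The step of a number 0.84 log units higher from compound 1 to compound 4 (beyond the scatter) shows that on this six-membered aromatic ring of carbon only, the place para to a large group accepts phenoxy, with its 7 heavy atoms and its own aromatic ring. In this assay the number still rises with this group in place. The earlier steps shown here had put only methoxy or methyl in place of hydrogen, so they said nothing about a group of this size. Nothing measured here explains the gain.

The compounds shown leave open whether the oxygen or the added ring carries the gain, and a plain methoxy or a benzyl group at the same place would separate the two. They also leave open how an amine or a carboxylic acid on the phenoxy ring would read in this assay for this series.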